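The compounds below may be only part of what the source reports. "The series", "measured", "known", "first", "only" and "open" are said of these compounds alone.

Measured so far in an assay on isolated protein for inhibition of Nitric oxide synthase, inducible (Homo sapiens), with a stated time of 30 min; a higher number here means a weaker inhibitor, a lower number a stronger inhibitor:
- compound 1 `Cc1cc(N)nc(CC(C)C)c1`: 193 nM
- compound 2 `Cc1cc(N)nc(CC(C)F)c1`: 220 nM
- compound 3 `C/C=C/c1cc(C)cc(N)n1`: 282 nM

On these numbers compound 2 sits second highest of the three; its nearest neighbour is compound 1, at a 1.1-fold higher number from compound 1 to compound 2 (0.06 log units; within the scatter), and the furthest is compound 3, at a 1.3-fold higher number from compound 2 to compound 3 (0.11 log units; within the scatter). All three values lie within the scatter of one another, so no order among them can be read.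

Compound 4 `COC(C)Cc1cc(C)cc(N)n1` is not yet measured. It differs from compound 2 by methoxy in place of fluoro on a saturated chain carbon bound to two saturated chain carbons.

The step that bears most directly on this change is the one at the same place on the chain, a 1.1-fold higher number from compound 1 to compound 2 (0.06 log units; within the scatter), which stayed within the scatter. The two steps that replace the whole chain, a 1.5-fold higher number from compound 1 to compound 3 (0.16 log units; within the scatter) and a 1.3-fold higher number from compound 2 to compound 3 (0.11 log units; within the scatter), also stayed within the scatter. Within the data shown here, nothing measured so far shows this assay to respond to what sits on that chain carbon, or to the chain as a whole, beyond the scatter. The expected step from compound 2 to compound 4 is therefore a 1.1-fold higher number from compound 2 to compound 4 (0.06 log units; within the scatter), in no firm direction. Compound 4 is estimated at 250 nM, with a range of 110 nM to 560 nM.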

Compound 4, half-maximal inhibitory concentration: > 5000 nM
Compound 4 ended at the assay's limit (the forecaster's own chance of this, stated with the estimate: 3%); middle value at least 20-fold (1.30 log units) from the limit.
By their numbers in this assay, from the lowest: compounds 1, 2 and 3 (each within the scatter of the next). At a limit, above all of these: compound 4.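

In this assay compound 4 gives > 5000 nM, which is a limit of the assay and not a number. Among these compounds, the chain carbon that looked silent in the earlier steps does respond to what it carries: an at least 22-fold higher number from compound 2 to compound 4 (1.35 log units; beyond the scatter), and an at least 25-fold higher number from compound 1 to compound 4 (1.41 log units; beyond the scatter). The assay therefore accepts methyl and fluoro at this place without a readable difference, but not methoxy, which enters with 2 heavy atoms and 1 hydrogen-bond acceptor where fluoro has 1 heavy atom and 0 hydrogen-bond acceptors.

Going by these compounds, whether the weakening goes with the oxygen or with the added carbon stays open, and a hydroxy or an ethyl on the same carbon would separate the two. On these data alone, the true value of compound 4 also stays open, so the full size of both steps is unknown.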